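The compounds below may be only part of what the source reports. "The series", "measured", "known", "first", "only" and "open" are said of these compounds alone.

Compound 3 `Cc1c(OCCCCOc2ccc(C(=O)O)cc2F)ccc(C(=O)CC2CCCC2)c1O` stands at the low end of the three values known in an assay on HEK293 cells for positive allosteric modulation of metabotropic glutamate receptor 3 (Rattus norvegicus), read by thallium flux, with a stated time of 2.5 min; a higher number here means a larger maximal response, a lower number a smaller maximal response: compound 3 gives 31.2%. Compound 1 `CCCC(=O)c1ccc(OCCCCOc2ccc(C(=O)O)cc2C)c(C)c1O` is its nearest neighbour, and in this assay compound 1 gives 40.5%, a value within the usual scatter of that of compound 3. Compound 2 `COc1ccc(C(=O)O)cc1OCCCCOc1ccc(C(=O)CC2CCCC2)c(O)c1C` is furthest away, with 67.6% in this assay. Among the measured compounds shown here, the only change at a single place among the measured compounds is the one from compound 2 to compound 3, where 4-carboxy-2-fluorophenyl replaced 5-carboxy-2-methoxyphenyl on an oxygen on a saturated carbon, and it gave a number 36.4 percentage points lower from compound 2 to compound 3 (beyond the scatter).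

Compound 4 `Cc1cc(C(=O)O)ccc1OCCCCOc1ccc(C(=O)CC2CCCC2)c(O)c1C` differs from compound 3 in one place: methyl in place of fluoro on an aromatic carbon. This is a smaller change than the measured step, since the carboxy group stays in place and only the fluoro is exchanged for methyl. Compound 1 carries the same 4-carboxy-2-methylphenyl as compound 4 and differs from it only elsewhere; its value and that of compound 3 lie within the scatter of each other. For the measured compounds named here, no measured step reports a fluoro-to-methyl exchange, so the direction is uncertain, and a step no larger than the scatter is expected, a number 8.8 percentage points higher from compound 3 to compound 4 (within the scatter). Compound 4 is therefore estimated at 40%, with a likely range from 27% to 56%.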

Compound 4, largest response reached (reported as percent of maximum), in percent of the reference or control that the assay uses: 28.4%
Beside the measured number, compound 4's estimate is 11.6 percentage points above it; low and high end bracket the measured number.
By their numbers in this assay, from the lowest: compounds 4, 3 and 1 (each within the scatter of the next, the first and the last beyond it); then compound 2.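

In this assay, the exchange of fluoro for methyl on this aromatic carbon, ortho to a large group and meta to a carboxy group, gave a number 2.8 percentage points lower from compound 3 to compound 4 (within the scatter) and so did not separate the two small groups at this position. The large fall first seen with the fluoro compound also held with methyl, as 4-carboxy-2-methylphenyl in place of 5-carboxy-2-methoxyphenyl gave a number 39.2 percentage points lower from compound 2 to compound 4 (beyond the scatter) and the high value of compound 2 therefore stayed apart from both. Among the compounds shown here, compound 4 also gave the first reading of a change at the other end of the molecule: with 4-carboxy-2-methylphenyl held constant, cyclopentyl in place of ethyl on a saturated chain carbon bound to a carbonyl carbon gave a number 12.1 percentage points lower from compound 1 to compound 4 (beyond the scatter) as a modest step.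

No supporting evidence accompanies these results to explain any of the steps. The compounds shown leave open whether chloro or trifluoromethyl on the same aromatic carbon, or an amide in place of the carboxy group, would stay within this low range of maximal response or move towards the value of compound 2.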